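The source may hold more compounds than are shown below. What is called first, only, known or untested is meant among the compounds shown, and "the series" means these compounds.

Measured so far in an assay for inhibition of Dihydrofolate reductase (Bos taurus), at pH 7.20; a lower number here means a less potent compound, a higher number a more potent compound, by a factor of ten per unit of this negative logarithm:
compound 1 `CC1(C)N=C(N)N=C(N)N1c1ccccc1F`: 5.41
compound 2 `CSc1ccccc1N1C(N)=NC(N)=NC1(C)C`: 3.91

Going by the values given here, compound 2 stands lowest of the two numbers; the only measured step, a number 1.50 log units lower from compound 1 to compound 2 (beyond the scatter), runs against it. Compound 3 `CC1(C)N=C(N)N=C(N)N1c1ccccc1C(F)(F)F` differs from compound 2 in one place: trifluoromethyl in place of methylsulfanyl on an aromatic carbon. Among the compounds with values here, no measured step involves a trifluoromethyl group, so the one step that bears here is the same a number 1.50 log units lower from compound 1 to compound 2 (beyond the scatter), which shows that the group on this aromatic carbon moves this assay strongly. A rise from compound 2 is expected, partly back toward compound 1, as a number 0.79 log units higher from compound 2 to compound 3 (beyond the scatter). For compound 3 the estimate in this assay is 4.7, with a range of 3.9 to 5.5.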

Compound 3, logarithm of the reciprocal of the active concentration, log(1/C): 3.53
Estimate against measurement, compound 3: 1.17 log units above; measured number below the stated range.
By their numbers in this assay, from the lowest: compound 3; then compound 2; then compound 1.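

In this assay this aromatic carbon, ortho to a large group, now carries three groups, with a number 0.38 log units lower from compound 2 to compound 3 (beyond the scatter) and a number 1.88 log units lower from compound 1 to compound 3 (beyond the scatter) in the record. Fluoro stands highest, and neither methylsulfanyl nor trifluoromethyl comes close to it. Trifluoromethyl also contains fluorine, yet compound 3 stands lowest of the three, and no supporting measurement on these compounds accounts for this order.

From the compounds shown here alone, whether any other group here could match fluoro remains open. Chloro, methyl, methoxy or an amine on this carbon would test how narrow that preference is.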